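The source may report more compounds than this note shows. Statements on the series, on what has been measured and on what is new or still open speak of the compounds shown alone.

Compound 2 `CCCCOc1ccc(NC(=O)Oc2ccccc2F)cc1` gives 340 nM in an assay on H4 cells for inhibition of Fatty-acid amide hydrolase 1 (Homo sapiens); a lower number here means a stronger inhibitor, a higher number a weaker inhibitor. Among the three numbers in hand it stands second highest. Compound 1 `O=C(Nc1ccc(Oc2ccccc2)cc1)Oc1ccccc1F` gives 1300 nM in this assay, and compound 3 `CCCCCCCCCCOc1ccc(NC(=O)Oc2ccccc2F)cc1` gives 9.2 nM. The two measured steps are a 3.8-fold lower number from compound 1 to compound 2 (0.58 log units; beyond the scatter) and a 37-fold lower number from compound 2 to compound 3 (1.57 log units; beyond the scatter); both alter the group on the oxygen on an aromatic ring, one modest, one large. Compound 4 `CCCCOc1ccc(NC(=O)Oc2ccc(F)cc2)cc1` differs from compound 2 in that (4-fluorophenyl in place of 2-fluorophenyl on an oxygen next to a carbonyl group). Neither measured step touches the fluorophenyl, so nothing in the series gives a direction for this change, and the expected step in this assay is none beyond the scatter, a 1.2-fold higher number from compound 2 to compound 4 (0.07 log units; within the scatter). Compound 4 is accordingly estimated at 400 nM, within a range of 150 nM to 1100 nM.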

Compound 4, half-maximal inhibitory concentration: 120 nM
For compound 4 the middle estimate is 3.3-fold (0.52 log units) above the measured one, outside the stated range (below it).
By their numbers in this assay, from the lowest: compound 3; then compound 4; then compound 2; then compound 1.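

In this assay, 4-fluorophenyl in place of 2-fluorophenyl on an oxygen next to a carbonyl group gives a 2.8-fold lower number from compound 2 to compound 4 (0.45 log units; beyond the scatter), a step beyond the scatter. Within the data shown here, the earlier steps changed only the group on the other oxygen, so this is the first sign that the number also responds at this position, here with the same atoms joined differently. Nothing available accounts for the step. Going by these compounds, whether the change holds with the longer chain of compound 3 remains open, as does how a plain phenyl or a chlorophenyl would compare at this position.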